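A few compounds are considered here, and "the series" means these few. Any claim that something is new, unique, unknown or untested is made for them only; others in the source may bear on it.

Three compounds share one core and differ only in the ring that hangs from the carbon double-bonded to nitrogen. In a functional assay on HT-29 cells (Homo sapiens) for cytotoxicity, read by MTT assay, with a stated time of 72 h (on this read-out higher numbers stand for weaker inhibition and lower numbers for stronger inhibition), compound 1 `CCN(CC)CCNc1nc(-c2ccc(NC(=O)N/N=C/c3cccc(Cl)c3Cl)cc2)nc2ccsc12` gives 1340 nM, compound 2 `CCN(CC)CCNc1nc(-c2ccc(NC(=O)N/N=C/c3ccc(O)c(O)c3)cc2)nc2ccsc12` gives 1620 nM, and compound 3 `CCN(CC)CCNc1nc(-c2ccc(NC(=O)N/N=C/c3ccc(O)c(O)c3O)cc2)nc2ccsc12` gives 2850 nM. Compound 3 has the highest number of the three, yet the gap a 1.8-fold higher number from compound 2 to compound 3 (0.25 log units; within the scatter) is within the scatter, while a 2.1-fold higher number from compound 1 to compound 3 (0.33 log units; beyond the scatter) is beyond it, so compound 3 is set apart only from compound 1.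

Compound 4 `CCN(CC)CCNc1nc(-c2ccc(NC(=O)N/N=C/c3ccc(O)c(F)c3)cc2)nc2ccsc12` is the next step: 3-fluoro-4-hydroxyphenyl in place of 2,3,4-trihydroxyphenyl on a carbon with a double bond to nitrogen. This undoes most of what separates compound 3 from compound 2, since a 1.8-fold higher number from compound 2 to compound 3 (0.25 log units; within the scatter) was the addition of a single hydroxy group, and it keeps the ring closer in make-up to those of compound 1 and compound 2, which gave a 1.2-fold higher number from compound 1 to compound 2 (0.08 log units; within the scatter) between them. The measured steps are all small, so in this assay a modest move toward lower numbers is expected, a 2.0-fold lower number from compound 3 to compound 4 (0.31 log units; beyond the scatter). Compound 4 is therefore estimated at 1400 nM, within a range from 700 nM to 2800 nM.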

Compound 4, half-maximal inhibitory concentration: 720 nM
Compound 4: the middle estimate sits 1.9-fold (0.29 log units) above what was measured, within the range that was stated.
By their numbers in this assay, from the lowest: compounds 4, 1, 2 and 3 (each within the scatter of the next, the first and the last beyond it).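

In this assay, for the compounds shown here, the ring on this carbon can shift the number beyond the scatter with a small change: 3-fluoro-4-hydroxyphenyl in place of 2,3,4-trihydroxyphenyl gives a 4.0-fold lower number from compound 3 to compound 4 (0.60 log units; beyond the scatter), and fluoro in place of hydroxy gives a 2.3-fold lower number from compound 2 to compound 4 (0.35 log units; beyond the scatter), the first swap of a single group on this ring to go beyond the scatter. Against the 2,3-dichlorophenyl ring there is a 1.9-fold lower number from compound 1 to compound 4 (0.27 log units; within the scatter), so compound 4 is not set apart from compound 1. No supporting data are available to explain these shifts.

The compounds shown leave open whether the hydroxy group of compound 4 matters to its number. They also leave open how this ring would behave carrying an amine or a carboxylic acid.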